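The source may report more compounds than this note shows. Statements on the series, on what has been measured and on what is new or still open speak of the compounds shown alone.

Of the compounds shown here, three built on a shared core have been measured in an assay on HEK293 cells for positive allosteric modulation of metabotropic glutamate receptor 5 (Homo sapiens), read by FLIPR; on this read-out higher numbers stand for an effect only at larger amounts of compound and lower numbers for an effect already at smaller amounts. Compound 1 `O=C([C@H]1CC2CCC1C2)N1CC(c2nc(-c3ccccc3)no2)C1` gives 120 nM, and compound 3 `O=C([C@H]1CC2CCC1C2)N1CC(c2nc(-c3cccc(F)c3)no2)C1` gives 72 nM. The step of a 1.7-fold lower number from compound 1 to compound 3 (0.22 log units; within the scatter) touches only the aromatic ring. Compound 2 `COC1CCN(C(=O)N2CC(c3nc(-c4cccc(Cl)c4)no3)C2)CC1` carries a different group on the carbonyl carbon than compound 1 does. In this assay compound 2 gives > 10000 nM, which is a limit of the assay and not a number. This is the limit of > 10000 nM in this assay, at which 1 of the 3 values shown sits, so for compound 2 there is no number, only this limit.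

Compound 4 `CC1CCN(C(=O)N2CC(c3nc(-c4cccc(Cl)c4)no3)C2)C1` differs from compound 2 in one place: 3-methylpyrrolidin-1-yl in place of 4-methoxypiperidin-1-yl on a carbonyl carbon. For the measured compounds named here, none of the measured steps bears on this change: the single measured step, between compound 1 and compound 3, alters the aromatic ring and lies within the scatter, and no pair of measured compounds differs in the group on the carbonyl carbon. Going by the values given here, the change therefore starts from a limit and has no measured counterpart to set its size or direction.

Compound 4 is expected to remain weak, with a step of an at least 1.2-fold lower number from compound 2 to compound 4 (0.09 log units; that floor lies within the scatter) whose size and direction are uncertain. For compound 4 the estimate in this assay is 8000 nM, within a range from 1500 nM to 30000 nM, and with a fair chance that only a limit is reported again.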

Compound 4, half-maximal effective concentration: > 10000 nM
Compound 4: only a limit was reported (the forecaster's own chance of this, stated with the estimate: 60%); middle value at least 1.2-fold (0.09 log units) from the limit.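

In this assay compound 4 gives > 10000 nM, which is a limit of the assay and not a number. Compound 2 also stands at a limit, and no step between compound 2 and compound 4 can be read: the limit of > 10000 nM in this assay, at which 2 of the 4 values shown sit.

The compounds shown leave open how 3-methylpyrrolidin-1-yl and 4-methoxypiperidin-1-yl compare on the carbonyl carbon.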